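The source may report more compounds than this note shows. Statements on the series, on what has been measured and on what is new or still open speak of the compounds shown alone.

Measured so far in an assay on cells for inhibition of Polyunsaturated fatty acid 5-lipoxygenase (Homo sapiens), read by HPLC, with stated times of 15 min and 10 min; on this read-out lower numbers stand for stronger inhibition and higher numbers for weaker inhibition:
- compound 1 `Clc1ccc2nc(-c3ccc(N4CCCCC4)cc3)c(NC3CCCCC3)n2c1` gives 140 nM
- compound 2 `Cc1ccc2nc(-c3ccccc3O)c(NC3CCCCC3)n2c1` gives 1900 nM
- compound 3 `Cc1ccc2nc(-c3cccc(Oc4ccccc4)c3)c(NC3CCCCC3)n2c1` gives 500 nM

Compound 2 stands at the highest number of the three, so it is the weakest inhibitor among them. Its nearest neighbour is compound 3, whose number is lower by a gap that lies beyond the usual scatter, and compound 1 sits furthest away, lower still. Among the measured compounds shown here, no pair of these measured compounds differs in only one place, so no single step can be read off from them; the three values only show that the aryl group on the shared core matters to the read-out.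

Compound 4 `Cc1ccc2nc(-c3ccncc3)c(NC3CCCCC3)n2c1` is not yet measured. It differs from compound 2 as follows:
pyridin-4-yl in place of 2-hydroxyphenyl on an aromatic carbon

For the measured compounds named here, with no comparable step among the measured compounds, the size of the step can only be guessed. Compound 2 holds the highest number, and both measured compounds carrying a different aryl group in this place give lower numbers, so a move toward a lower number is expected, though possibly one that does not clear the scatter. Compound 4 is therefore estimated at 1200 nM, with a range from 400 nM to 4000 nM. This estimate means a step of a 1.6-fold lower number from compound 2 to compound 4 (0.20 log units; within the scatter), expected to be small.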

Compound 4, half-maximal inhibitory concentration: 7200 nM
Beside the measured number, compound 4's estimate is 6.0-fold (0.78 log units) below it; the measured number lies above the stated range.
By their numbers in this assay, from the lowest: compound 1; then compound 3; then compound 2; then compound 4.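

Among the compounds shown here, replacing 2-hydroxyphenyl with pyridin-4-yl on this aromatic carbon gives, in this assay, a 3.8-fold higher number from compound 2 to compound 4 (0.58 log units; beyond the scatter), the first step that can be read directly. It shows that a change at this place alone, with the cyclohexylamino group and the rest of the shared core held constant, moves the number beyond the scatter, and here the move is toward weaker inhibition. The change removes a hydrogen-bond donor and brings a ring nitrogen into the aromatic ring, so this one step cannot separate those two differences, and no measurement at hand gives a reason for it.

The compounds shown leave open whether the higher number follows from losing the hydroxyl group or from gaining the ring nitrogen, a question that plain phenyl at this carbon would help to settle. Also open, from the compounds shown here alone, is whether the placement of either atom matters, which 4-hydroxyphenyl, 2-methoxyphenyl and pyridin-3-yl at the same carbon could test against compound 2 and compound 4.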